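The compounds below may be only part of what the source reports. "The series", "measured", "known", "first", "only" and "open" are said of these compounds alone.

Compound 1 `OCCCCCC(O)c1ccc(-c2ccc(Cl)cc2)cc1`: 17000 nM
Compound 2 `OCCCCCC(O)c1ccc(-c2ccc(C(F)(F)F)cc2)cc1`: 13000 nM

In a functional assay on J774 cells (Mus musculus) for cytotoxicity, read by resazurin assay (a lower number here means a stronger inhibitor, a higher number a weaker inhibitor), compound 2 gives 13000 nM and so stands within the scatter of compound 1 (17000 nM). Compound 3 `OCCCCCC(O)c1ccc(-c2ccc(OC(F)(F)F)cc2)cc1` has trifluoromethoxy in place of trifluoromethyl on an aromatic carbon. For the measured compounds named here, only one measured step bears on this, trifluoromethyl in place of chloro on an aromatic carbon, and it is small (a 1.3-fold lower number from compound 1 to compound 2 (0.12 log units; within the scatter)). On that single step, no change beyond the scatter is expected in this assay. The expected step is small (a 1.1-fold lower number from compound 2 to compound 3 (0.03 log units; within the scatter)). For compound 3 the estimated value is 12000 nM with an expected range from 6000 nM to 25000 nM.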

Compound 3, half-maximal inhibitory concentration: 14000 nM
The estimate for compound 3 lay 1.2-fold (0.07 log units) below the measured number; the measured number falls inside the stated range.
By their numbers in this assay, from the lowest: compounds 2, 3 and 1 (each within the scatter of the next).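

Trifluoromethoxy, which adds an oxygen and a hydrogen-bond acceptor on the aromatic carbon para to a large group, stays within the scatter in this assay against both trifluoromethyl (a 1.1-fold higher number from compound 2 to compound 3 (0.03 log units; within the scatter)) and chloro (a 1.2-fold lower number from compound 1 to compound 3 (0.08 log units; within the scatter)). Compound 1, compound 2 and compound 3 thus read alike, so this third group adds no separation at this position. No available evidence bears on this result. From the compounds shown here alone, whether an amine or a carboxylic acid at this position would move the number beyond the scatter stays open.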